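Ring Size at the Amine: From Compound 3 to Compound 4

The source may hold more compounds than are shown below. What is called first, only, known or untested is meant among the compounds shown, and "the series" means these compounds.

Measured compounds:
compound 1 `CCNc1nc(-c2ccccc2)nc2c1nnn2Cc1ccccc1C(F)(F)F` — "not determined" (no result reported)
compound 2 `CCCNc1nc(-c2ccccc2)nc2c1nnn2Cc1ccccc1C(F)(F)F` — "not determined" (no result reported)
compound 3 `FC(F)(F)c1ccccc1Cn1nnc2c(NC3CC3)nc(-c3ccccc3)nc21` — 7.8 nM

For the measured compounds named here, compound 3 holds the only number in this set: in an assay on Cerebral cortex for displacement of a labelled ligand from adenosine receptor A1 (Bos taurus) (a lower number here means a stronger inhibitor, a higher number a weaker inhibitor), compound 3 gives 7.8 nM, while compound 1 stands at "not determined" (no result reported) and compound 2 at "not determined" (no result reported), so no step between measured compounds can be drawn. Compound 4 `FC(F)(F)c1ccccc1Cn1nnc2c(NC3CCCC3)nc(-c3ccccc3)nc21` differs from compound 3 in one place: cyclopentyl in place of cyclopropyl on a nitrogen on an aromatic ring. With nothing else to go on, a modest change is expected, and a small gain rather than a loss, with the step of a 1.6-fold lower number from compound 3 to compound 4 (0.19 log units; within the scatter) expected to stay near the usual scatter. For compound 4 the estimate is 5 nM, in the range 1.5 nM to 20 nM.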

Compound 4, inhibition constant: 0.6 nM
Beside the measured number, compound 4's estimate is 8.3-fold (0.92 log units) above it; the measured number lies below the stated range.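

In this assay, replacing cyclopropyl with cyclopentyl on a nitrogen on an aromatic ring gives a 13-fold lower number from compound 3 to compound 4 (1.11 log units; beyond the scatter), so this position responds strongly to the size of the carbon ring. For the compounds shown here, this is the first readable step at this position, and steps involving compound 1 or compound 2 cannot be read. No available evidence accounts for the gain. From the compounds shown here alone, it remains open whether a cyclobutyl or cyclohexyl ring would give a still lower number, and whether a hydroxyl group on the cyclopentyl ring would be tolerated.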